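Cyclic Amine Swap in a Fatty Acid Receptor Agonist Series

This account rests on a few compounds, and the source may have more. Where it says the series, first, only, none or still open, it means among the compounds named here.

Compound 1 `Cc1cccc(C)c1-c1cccc(COc2ccc3c(c2)OCC3CC(=O)O)c1` gives 62.6% in a functional assay on CHO cells for agonist activity at Free fatty acid receptor 1 (Homo sapiens), read by FLIPR and calcium flux, with a stated time of 90 s, tested at 100 nM (on this read-out higher numbers stand for a stronger effect at the one concentration tested and lower numbers for a weaker effect), the highest of the two numbers measured, while compound 2 `O=C(O)CC1COc2cc(OCc3cccc(N4CCCCC4)c3)ccc21` gives 34.7%. Among the compounds with values here, the single measured step, a number 27.9 percentage points lower from compound 1 to compound 2 (beyond the scatter), bears directly on compound 3 `O=C(O)CC1COc2cc(OCc3cccc(N4CCCC4)c3)ccc21`, which differs from compound 1 by pyrrolidin-1-yl in place of 2,6-dimethylphenyl on an aromatic carbon. Pyrrolidin-1-yl, like piperidin-1-yl in compound 2, replaces the 2,6-dimethylphenyl group, so a downward step of comparable size in this assay is expected. Compound 3 is therefore estimated at 35%, between 20% and 50%, which means an expected step of a number 27.6 percentage points lower from compound 1 to compound 3 (beyond the scatter).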

Compound 3, a percentage reported as activity, at one concentration (the size of the read-out at that concentration, not a potency): 43.7%
Beside the measured number, compound 3's estimate is 8.7 percentage points below it, and the stated range covers the measured number.
By their numbers in this assay, from the lowest: compounds 2 and 3 (each within the scatter of the next); then compound 1.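

Replacing 2,6-dimethylphenyl with a second cyclic amine again gives a drop beyond the scatter, with a number 18.9 percentage points lower from compound 1 to compound 3 (beyond the scatter) in this assay and so this loss is not confined to the piperidin-1-yl group. Contracting the ring gives a number 9 percentage points higher from compound 2 to compound 3 (within the scatter) and so this read-out does not separate the two cyclic amines. The data offer no explanation for either step.

From the compounds shown here alone, it remains open whether an open-chain amine such as diethylamino or a morpholine ring would match these two amines or approach compound 1. An unsubstituted phenyl ring would show whether the two methyl groups matter here.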